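Amine exchange on the chain of compound 1

The source may report more compounds than this note shows. Statements on the series, on what has been measured and on what is new or still open speak of the compounds shown alone.

Compound 1 `CCN(CC)CN1C(=O)/C(=N\c2nc3ccc(C)cc3s2)c2c(Br)cccc21` stands lowest of the three numbers in an ADME assay on 184B5 cells (Homo sapiens) for cytotoxicity, read by sulforhodamine B assay, with a stated time of 48 h (on this read-out higher numbers stand for weaker inhibition of growth and lower numbers for stronger inhibition of growth), giving 34300 nM. Compound 2 `O=C1C(=O)N(CN(c2ccccc2)c2ccccc2)c2cccc(Cl)c21` gives 96800 nM and compound 3 `O=C1C(=O)N(CN(c2ccccc2)c2ccccc2)c2cccc(Br)c21` gives 98500 nM; each of these lies beyond the scatter away from compound 1. Among the compounds with values here, the only measured step, a 1.0-fold higher number from compound 2 to compound 3 (0.01 log units; within the scatter), concerns a halogen exchange on an aromatic carbon and says nothing about the chain carried by the amide-type nitrogen. Compound 4 `Cc1ccc2nc(/N=C3\C(=O)N(CN4CCCCC4)c4cccc(Br)c43)sc2c1` differs from compound 1 by piperidin-1-yl in place of diethylamino on a saturated chain carbon bound to an amide-type nitrogen in a ring. Within the data shown here, no measured step covers this change, so the expectation rests on the modest size of the exchange and on compound 1 at 34300 nM. A step of about a 1.1-fold lower number from compound 1 to compound 4 (0.03 log units; within the scatter) is expected, which is to say none beyond the scatter in this assay. Compound 4 is therefore estimated at 32000 nM, with a range from 12000 nM to 85000 nM. A result well outside that range would indicate that the chain amine matters more here than the other two compounds can show.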

Compound 4, concentration for 50% growth inhibition: 85200 nM
Compound 4: the middle estimate sits 2.7-fold (0.43 log units) below what was measured; measured number outside the range, above it.
By their numbers in this assay, from the lowest: compound 1; then compounds 4, 2 and 3 (each within the scatter of the next).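

In this assay, piperidin-1-yl in place of diethylamino on a saturated chain carbon bound to an amide-type nitrogen in a ring gives a 2.5-fold higher number from compound 1 to compound 4 (0.40 log units; beyond the scatter) and so moves the read-out towards weaker inhibition of growth. Within the data shown here, the only earlier step concerned a halogen on an aromatic carbon, so this is the first sign that the amine on this chain affects the number while the core of compound 1 stays the same. No evidence at hand bears on the reason for this step.

A single exchange cannot show whether the step belongs to the piperidine ring in particular or to any departure from diethylamino. Pyrrolidin-1-yl, morpholin-4-yl or dimethylamino on the same chain would help to separate these readings.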